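Working notes on four thioethers and a cytotoxicity limit

The source may report more compounds than this note shows. Statements on the series, on what has been measured and on what is new or still open speak of the compounds shown alone.

Measured compounds:
compound 1 `C#CCSc1nnc(CC)n1N1C(=O)c2ccccc2C1=O`
compound 2 `CCc1nnc(SCC(=O)c2ccc(Cl)cc2)n1N1C(=O)c2ccccc2C1=O`
compound 3 `C#CCSc1nnc(-c2cc(OC)c(OC)c(OC)c2)n1N1C(=O)c2ccccc2C1=O`
Not yet measured:
compound 4 `COc1cc(-c2nnc(SCC(=O)c3ccc(F)cc3)n2N2C(=O)c3ccccc3C2=O)cc(OC)c1OC`

In a functional assay on HepG2 cells (Homo sapiens) for cytotoxicity, read by MTT assay, with a stated time of 48 h (a lower number here means a stronger inhibitor, a higher number a weaker inhibitor), compound 1 gives > 200000 nM, a limit of the assay. Compound 2 gives > 200000 nM, also a limit. Compound 3 stands at > 200000 nM, again a limit of the assay. All three values sit at the limit of > 200000 nM in this assay, at which 3 of the 3 values shown sit, so compound 3 is not separated from the other two. The change to compound 4 is (4-fluorophenyl)carbonyl in place of ethynyl on a saturated chain carbon bound to a sulfur. For the measured compounds named here, the only measured step of this kind, a step that the two limits leave unreadable from compound 1 to compound 2, cannot be read, since both ends are limits. No direction can therefore be fixed; the expected step that the limit leaves unreadable from compound 3 to compound 4 is none beyond the scatter. Compound 4 is estimated at 250000 nM, within 50000 nM to 1000000 nM, most probably reported again as a limit.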

Compound 4, half-maximal inhibitory concentration: > 200000 nM
Compound 4 ended at the assay's limit; the forecaster's own chance of this, stated with the estimate: 75%; the middle value lies beyond the limit too.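

No step can be read from compound 3 to compound 4, as both values are limits: the limit of > 200000 nM in this assay, at which 4 of the 4 values shown sit. The compounds shown leave open whether ethynyl or (4-fluorophenyl)carbonyl makes any difference in this assay at all.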